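The source may report more compounds than this note shows. Statements on the series, on what has been measured and on what is new or still open speak of the compounds shown alone.

Two compounds anchor this account. Compound 1 `CCOc1ccc(/C=C(/Sc2ccc(C)cc2)C(=O)c2ccc(Cl)cc2)cc1OC` and compound 2 `CSc1ccc(/C=C(\C(=O)c2ccc(Cl)cc2)S(=O)(=O)Cc2ccc(C)cc2)cc1` were both tested in a functional assay on DU-145 cells (Homo sapiens) for inhibition, read by trypan blue exclusion, with a stated time of 96 h; a higher number here means a weaker inhibitor of growth, a lower number a stronger inhibitor of growth. In this assay compound 1 gives 25000 nM, while compound 2 gives 10000 nM in this assay, the lower of the two numbers, with compound 1 standing a clear distance higher, beyond the usual scatter. Compound 3 `CCOc1ccc(/C=C(\C(=O)c2ccc(Cl)cc2)S(=O)(=O)Cc2ccc(C)cc2)cc1OC` has not yet been measured. It differs from compound 2 in one place: 4-ethoxy-3-methoxyphenyl in place of 4-(methylsulfanyl)phenyl on a double-bonded chain carbon bound to a double-bonded chain carbon. Compound 1 carries the same 4-ethoxy-3-methoxyphenyl group, but it also differs from compound 2 elsewhere, so the two measured values alone cannot isolate the effect of this exchange. The expected step from compound 2 to compound 3 is a 1.5-fold higher number from compound 2 to compound 3 (0.18 log units; within the scatter), modest and toward a weaker inhibitor of growth, near the edge of the scatter. Compound 3 is therefore estimated at 15000 nM in this assay, with a range from 5000 nM to 45000 nM.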

Compound 3, concentration for 50% growth inhibition: 10000 nM
The estimate for compound 3 lay 1.5-fold (0.18 log units) above the measured number, and the stated range covers the measured number.
By their numbers in this assay, from the lowest: compounds 2 and 3 (each within the scatter of the next); then compound 1.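

In this assay, 4-ethoxy-3-methoxyphenyl in place of 4-(methylsulfanyl)phenyl on a double-bonded chain carbon bound to a double-bonded chain carbon gives no change at the digits printed from compound 2 to compound 3 (within the scatter), so the numbers do not separate these two groups at this position. Compound 3 also isolates a second exchange: (4-methylbenzyl)sulfonyl in place of (4-methylphenyl)sulfanyl on a double-bonded chain carbon bound to a carbonyl carbon and a double-bonded chain carbon gives a 2.5-fold lower number from compound 1 to compound 3 (0.40 log units; beyond the scatter). Going by these compounds alone, of the two exchanges, only this one carries a step beyond the scatter.

As far as these compounds go, how an amine or a carboxylic acid in place of either aromatic group would read in this assay remains open. Nothing measured here accounts for either step.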